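From a carboxy side chain to an aminopropyl one

A few compounds are considered here, and "the series" means these few. Any claim that something is new, unique, unknown or untested is made for them only; others in the source may bear on it.

Measured in an ADME assay on a cell-free system (plasma, Homo sapiens) for metabolic stability (on this read-out higher numbers stand for a longer-lived compound and lower numbers for a shorter-lived compound), so far:
compound 1 `CCCN(CCC)Cc1cccc(C(=O)OCCOCn2cnc3c(=O)[nH]c(N)nc32)c1` gives 0.0133 h
compound 2 `N[C@@H](CC(=O)O)C(=O)O[C@H]1C[C@H](n2cc(F)c(=O)[nH]c2=O)O[C@@H]1CO` gives 0.898 h
compound 3 `CCCCC(=O)OCn1cnc2c1c(=O)n(C)c(=O)n2C` gives 0.00317 h

Compound 2 stands highest of the three at 0.898 h on this half-life read-out. Compound 1 lies at 0.0133 h and compound 3 at 0.00317 h and both gaps to compound 2 are beyond the scatter.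

Compound 4 `NCCCC[C@H](N)C(=O)O[C@H]1C[C@H](n2cc(F)c(=O)[nH]c2=O)O[C@@H]1CO` has not yet been measured. It differs from compound 2 in one place (3-aminopropyl in place of carboxy on a saturated chain carbon, two bonds along the chain from an amine nitrogen and a carbonyl carbon): 3-aminopropyl in place of carboxy on a saturated chain carbon, two bonds along the chain from an amine nitrogen and a carbonyl carbon. Among the compounds with values here, no measured pair isolates this change, so the data give no direct guide to its size in this assay and any forecast is tentative. Neither compound 1 nor compound 3 carries a carboxy group, and both are shorter-lived than compound 2 at 0.898 h even though they differ from it in much else. On that thin evidence, a downward move is expected. The expected step is a 3.0-fold lower number from compound 2 to compound 4 (0.48 log units; beyond the scatter) and would be a shortening modestly beyond the scatter. For compound 4 the estimated half-life is 0.3 h with an expected range from 0.07 h to 1.2 h as its bounds.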

Compound 4, half-life: 0.85 h
For compound 4 the middle estimate is 2.8-fold (0.45 log units) below the measured one; measured number inside the range.
By their numbers in this assay, from the lowest: compound 3; then compound 1; then compounds 4 and 2 (each within the scatter of the next).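

In this assay, within the data shown here, this pair is the first to isolate a single change at this position, and replacing carboxy with 3-aminopropyl on a saturated chain carbon, two bonds along the chain from an amine nitrogen and a carbonyl carbon, gives a 1.1-fold lower number from compound 2 to compound 4 (0.02 log units; within the scatter) and so leaves the half-life indistinguishable between the two compounds. At this place, then, the carboxy group is not required for a half-life at the level of compound 2, since a side chain ending in an amine rather than a carboxylic acid reads the same within the scatter. Nothing available here explains why the two side chains read alike.

The pair leaves open whether this tolerance extends to other groups at the same place, such as a plain butyl chain with no terminal amine, a shorter aminomethyl chain, or a carboxylic acid carried on a longer chain. A single pair on one shared core also cannot say whether the same exchange would read alike on a different core, or whether it would hold in any medium other than this one.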